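Replacing the hydroxy group: what to expect of compound 4

The source may report more compounds than this note shows. Statements on the series, on what has been measured and on what is new or still open speak of the compounds shown alone.

Measured so far in a functional assay on U-251 cells (Homo sapiens); on this read-out lower numbers stand for stronger inhibition of growth and higher numbers for weaker inhibition of growth:
compound 1 `O=S(=O)(/C=C/c1ccc(Br)cc1)Cc1ccc(Nc2ncnc3ccc(Br)cc23)cc1` gives 11000 nM
compound 2 `O=S(=O)(/C=C/c1ccc(Cl)cc1)Cc1ccc(Nc2ncnc3ccc(Br)cc23)cc1` gives 30000 nM
compound 3 `O=S(=O)(/C=C/c1ccc(O)cc1)Cc1ccc(Nc2ncnc3ccc(Br)cc23)cc1` gives > 100000 nM

For compound 3 the reading is a limit of the assay and not a number, so any step from it has only a bound on its size.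

Compound 4 `O=S(=O)(/C=C/c1ccc(F)cc1F)Cc1ccc(Nc2ncnc3ccc(Br)cc23)cc1` carries 2,4-difluorophenyl in place of 4-hydroxyphenyl on a double-bonded chain carbon bound to a double-bonded chain carbon and is not yet measured.

The nearest evidence is the pair of halogen-to-hydroxy steps, an at least 9.0-fold higher number from compound 1 to compound 3 (0.95 log units; beyond the scatter) and an at least 3.3-fold higher number from compound 2 to compound 3 (0.52 log units; beyond the scatter), which read in reverse for a move away from hydroxy. Among the halogens, a 2.7-fold higher number from compound 1 to compound 2 (0.44 log units; beyond the scatter) also counts. Going by the values given here, no fluoro compound has been measured, so the size rests on these steps alone. Among the compounds with values here, a lower number than that of compound 3 is expected in this assay, with a size nearer the step from compound 2 than the one from compound 1.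

The expected step, an estimate only, is an at least 3.3-fold lower number from compound 3 to compound 4 (0.52 log units; beyond the scatter) and no more than that is assumed.

The estimate for compound 4 is 30000 nM with 9000 nM to 100000 nM as its expected range.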

Compound 4, concentration for 50% growth inhibition: 32000 nM
Estimate against measurement, compound 4: 1.1-fold (0.03 log units) below; low and high end bracket the measured number.
By their numbers in this assay, from the lowest: compound 1; then compounds 2 and 4 (each within the scatter of the next). At a limit, above all of these: compound 3.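

In this assay, 2,4-difluorophenyl gives a readable value where 4-hydroxyphenyl gave none, with an at least 3.1-fold lower number from compound 3 to compound 4 (0.49 log units; beyond the scatter). That step is only a bound, as compound 3 stands at a limit of the assay: the limit of > 100000 nM in this assay, at which 1 of the 4 values shown sits.

The two fluoro atoms of 2,4-difluorophenyl and the single chloro of 4-chlorophenyl are not separated at this place, with a 1.1-fold higher number from compound 2 to compound 4 (0.03 log units; within the scatter), whereas 4-bromophenyl still stands apart, with a 2.9-fold higher number from compound 1 to compound 4 (0.46 log units; beyond the scatter), so among the three halogen-bearing compounds only compound 1 differs beyond the scatter.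

From the compounds shown here alone, what each fluoro atom contributes stays open, as does the behaviour of a phenyl ring carrying a single fluoro, a methoxy or an amine at this place. Going by these compounds, whether iodo or trifluoromethyl would give a lower number than compound 1 is also open.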